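The source may hold more compounds than are shown below. What is called first, only, known or untested is meant among the compounds shown, and "the series" means these compounds.

Measured compounds:
Compound 1, `N#CC1=C(N)Oc2c(c3nc4ccccc4nc3c3ccccc23)C12C(=O)N(Cc1cnnn1-c1ccc(F)cc1)c1ccccc12`, in an ADME assay on L02 cells (Homo sapiens) for antiproliferative activity, read by MTT assay, with a stated time of 48 h (on this read-out lower numbers stand for stronger inhibition and higher numbers for weaker inhibition), compound 1 gives > 50000 nM, which is a limit of the assay rather than a number.
Compound 2, `COc1ccc(-n2nncc2CN2C(=O)C3(C(C#N)=C(N)Oc4c3c3nc5ccccc5nc3c3ccccc43)c3ccccc32)cc1`, in this assay compound 2 gives > 50000 nM, again a limit of the assay.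
Compound 3, `N#CC1=C(N)Oc2c(c3nc4ccccc4nc3c3ccccc23)C12C(=O)N(Cc1cnnn1-c1ccc(S(N)(=O)=O)cc1)c1ccccc12`, in this assay compound 3 gives > 50000 nM, also a limit of the assay.

Compound 2 therefore stands only at a limit of the assay, and no number for it is known. All three measured compounds sit together at the limit of > 50000 nM in this assay, at which 3 of the 3 values shown sit, so the steps among them cannot be read: a step that the two limits leave unreadable from compound 1 to compound 2, a step that the two limits leave unreadable from compound 1 to compound 3 and a step that the two limits leave unreadable from compound 2 to compound 3 are all unreadable.

Compound 4 is `Cc1ccc(-n2nncc2CN2C(=O)C3(C(C#N)=C(N)Oc4c3c3nc5ccccc5nc3c3ccccc43)c3ccccc32)cc1Cl`. It differs from compound 2 as follows: 3-chloro-4-methylphenyl in place of 4-methoxyphenyl on an aromatic nitrogen. Going by the values given here, no measured step bears on this change, since every value so far is a limit. The measured compounds only show that changes on this aromatic ring have not produced a readable number. Compound 4 is therefore expected to remain at or beyond the limit, a step that the limit leaves unreadable from compound 2 to compound 4 being expected. The estimate for compound 4 is 80000 nM, with a range from 30000 nM to 200000 nM.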

Compound 4, half-maximal inhibitory concentration: > 50000 nM
Compound 4: only a limit was reported; the forecaster's own chance of this, stated with the estimate: 85%; the middle value does not contradict the limit.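

In this assay compound 4 gives > 50000 nM, a limit and not a number. Its steps to compound 1, compound 2 and compound 3 therefore cannot be read, as all four compounds sit at the same limit: the limit of > 50000 nM in this assay, at which 4 of the 4 values shown sit.

The compounds shown leave open whether changing the group on the aromatic nitrogen alters this read-out at all.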